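One Group Swap on a Compound Sitting at a Limit

The compounds below may be only part of what the source reports. "The series", "measured", "known", "first", "only" and "open" are said of these compounds alone.

In an ADME assay on HUVEC cells (Homo sapiens) for cytotoxicity, read by MTT assay, with a stated time of 24 h (on this read-out lower numbers stand for stronger inhibition and higher numbers for weaker inhibition), compound 1 `C[C@@H]1O[C@@]1(C)C(=O)C[C@@H]1[C@@]2(C)[C@@H](O)CCC(C)(C)[C@]2(O)CC[C@@]1(C)O` gives > 10000 nM, which is a limit and not a number. Compound 2 `C[C@@H]1O[C@@]1(C)C(=O)C[C@H]1[C@](C)(O)CC[C@@]2(O)C(C)(C)CCC[C@]12C` gives > 10000 nM, which is also a limit. The two compounds share that position: the limit of > 10000 nM in this assay, at which 2 of the 2 values shown sit.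

Compound 3 `C/C=C(\C)C(=O)C[C@H]1[C@](C)(O)CC[C@@]2(O)C(C)(C)CCC[C@]12C` differs from compound 2 in one group: 1-methylprop-1-en-1-yl in place of 2,3-dimethyloxiran-2-yl on a carbonyl carbon. In words, 1-methylprop-1-en-1-yl stands in place of 2,3-dimethyloxiran-2-yl on a carbonyl carbon. Going by the values given here, the only measured step, a step that the two limits leave unreadable from compound 1 to compound 2, puts hydrogen in place of hydroxy on a saturated ring carbon. It is a different change and has no readable size, and no measurement covers the new group. No step beyond the scatter can therefore be predicted in this assay. The expected result is a step that the limit leaves unreadable from compound 2 to compound 3. For compound 3, the estimated value is 15000 nM, with an expected range from 8000 nM to 40000 nM.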

Compound 3, half-maximal inhibitory concentration: > 10000 nM
Compound 3 gave a limit, no number; the forecaster's own chance of this, stated with the estimate: 85%; the middle value is on the limit's open side.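

In this assay compound 3 gives > 10000 nM which is a limit and not a number. Compound 2 also sits at a limit, so no step can be read between compound 2 and compound 3. Whether swapping 2,3-dimethyloxiran-2-yl for 1-methylprop-1-en-1-yl changes the read-out at all stays open, with all the compounds shown in one position: the limit of > 10000 nM in this assay, at which 3 of the 3 values shown sit.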